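Trimming the aryl-nitrogen substituent of compound 2

A few compounds are considered here, and "the series" means these few. Any claim that something is new, unique, unknown or untested is made for them only; others in the source may bear on it.

Among the compounds with values here, compound 2 `Cc1noc(NS(=O)(=O)c2cccc3c(NC(=O)C(C)C)cccc23)c1C` gives 880 nM in an assay on VSM-A10 cells for antagonist activity at Endothelin-1 receptor (Rattus norvegicus) (a lower number here means a stronger inhibitor, a higher number a weaker inhibitor), the lower of the two numbers so far; compound 1 `Cc1noc(NS(=O)(=O)c2ccc(NCc3ccccc3)cc2)c1C` gives 9800 nM in this assay, a gap beyond the scatter. Compound 3 `CNc1cccc2c(S(=O)(=O)Nc3onc(C)c3C)cccc12` is not yet measured. It differs from compound 2 in one place: methyl in place of isopropylcarbonyl on a nitrogen on an aromatic ring, which one bond further out reads (isopropylcarbonyl)amino to methylamino. Within the data shown here, no measured pair shows this change, so its size rests on judgement alone; a moderate weakening beyond the scatter is expected. Compound 3 is expected near 2500 nM, with a range from 800 nM to 8000 nM. The expected step is a 2.8-fold higher number from compound 2 to compound 3 (0.45 log units; beyond the scatter).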

Compound 3, half-maximal inhibitory concentration: 130 nM
Compound 3: middle estimate off by 19-fold (1.28 log units), on the high side; the whole stated range lies above it.
By their numbers in this assay, from the lowest: compound 3; then compound 2; then compound 1.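

Methyl in place of isopropylcarbonyl on a nitrogen on an aromatic ring gives a 6.8-fold lower number from compound 2 to compound 3 (0.83 log units; beyond the scatter) in this assay. At this position, then, the isopropylcarbonyl is not required for activity, and the methylamino form is the stronger of the two. No measurement at hand gives a reason for this step.

This single pair removes the carbonyl and shrinks the substituent at once, so the two changes cannot be told apart. An acetyl group, an ethyl group or a free amine on the same nitrogen would separate them.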